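The source may hold more compounds than are shown below. What is called first, only, known or untested is meant among the compounds shown, and "the series" means these compounds.

Of the compounds shown here, two have been read so far in a functional assay (brain) for inhibition, with Mus musculus as the target; on this read-out lower numbers stand for stronger inhibition and higher numbers for weaker inhibition. Compound 1 `CN(C)CC/C=C(/c1ccc(Br)cc1)c1cccnc1` gives > 24000 nM, which is a limit and not a number. Going by the values given here, compound 2 `CNCC/C=C(\c1ccc(Br)cc1)c1cccnc1` gives 250 nM, the only actual number in the set, and so the sole numerical reference point. The next compound to be read is compound 3 `CNCC/C=C(/c1ccc(Br)cc1)c1cccnc1`. Its relation to compound 2 is purely one of geometry: the two compounds have the same atoms and bonds and differ only in configuration as drawn: 1 of 1 stereo elements differ; a double bond is drawn E in compound 2 and Z in compound 3. Nothing leaves and nothing enters, so any difference between the two readings will belong to that one double bond. Among the compounds with values here, no measured step between two compounds is available to scale such a change. Even so, compound 2 at 250 nM is a fairly strong reading, and the switch in configuration is expected to move the result toward weaker inhibition, beyond the scatter. The estimated change is a 4.8-fold higher number from compound 2 to compound 3 (0.68 log units; beyond the scatter). For compound 3 the expected value in this assay is 1200 nM, with an estimated range from 250 nM to 6000 nM.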

Compound 3, half-maximal inhibitory concentration: > 25000 nM
Compound 3 ended at the assay's limit; the forecaster's own chance of this, stated with the estimate: 12%; middle value at least 20-fold (1.31 log units) away from the limit.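

In this assay, the whole of the change lies in one double bond, and it gives an at least 100-fold higher number from compound 2 to compound 3 (2.00 log units; beyond the scatter), a large step beyond the scatter: the fact that compounds 2 and 3 differ only in the configuration as drawn. Going by these compounds, compound 3 gives > 25000 nM, which is a limit of the assay and not a number, so the true size of the step remains unknown, and it may be larger than the figure printed with it. The step from compound 1 to compound 3, hydrogen in place of methyl on an amine nitrogen, cannot be read, and the set therefore gives no measure of what that methyl does in this configuration.

The compounds shown leave open whether the same methyl on the amine nitrogen would change the reading in the configuration of compound 2, the only one here with an actual number. They also leave open whether that configuration would hold its reading with a chlorine in place of the bromine, or with a longer chain leading to the amine.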